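Replacing the hydrazide amino group with an indolinone hydrazone

The source may report more compounds than this note shows. Statements on the series, on what has been measured and on what is new or still open speak of the compounds shown alone.

Measured compounds:
- compound 1, `Cc1n[nH]c2c1C(c1ccc(N(C)C)cc1)C(C(=O)NN)=C(N)N2`, 51300 nM
- compound 2, `Cc1n[nH]c2c1C(c1ccc(N(C)C)cc1)C(C(=O)NNC(N)=S)=C(N)N2`, 6260 nM
- compound 3, `Cc1n[nH]c2c1C(c1ccc(N(C)C)cc1)C(C(=O)NNc1cc([N+](=O)[O-])ccc1[N+](=O)[O-])=C(N)N2`, 8520 nM

All three share one core, differing only at the terminal nitrogen of the hydrazide. In a functional assay on HeLa cells (Homo sapiens) for cytotoxicity, read by MTT assay, with a stated time of 48 h (on this read-out lower numbers stand for stronger inhibition and higher numbers for weaker inhibition), compound 1 gives 51300 nM, the highest of the three numbers, so it is the weakest of the measured compounds in this assay. Two steps start from it. Replacing the terminal hydrogen gave an 8.2-fold lower number from compound 1 to compound 2 (0.91 log units; beyond the scatter) and a 6.0-fold lower number from compound 1 to compound 3 (0.78 log units; beyond the scatter), both modest and both beyond the scatter, while between the two substituted compounds the difference is a 1.4-fold higher number from compound 2 to compound 3 (0.13 log units; within the scatter). The unmeasured compound 4, `Cc1n[nH]c2c1C(c1ccc(N(C)C)cc1)C(C(=O)N/N=C1/C(=O)Nc3ccccc31)=C(N)N2`, goes further in the same direction: a group of 11 heavy atoms (8 carbon, 2 nitrogen, 1 oxygen; one five-membered non-aromatic ring with 1 hetero atom, one six-membered aromatic ring of carbon only) in place of one nitrogen atom, on an amide-type nitrogen. Both measured steps from compound 1 suggest that building out at this nitrogen gives a modest drop in the number, whatever the group. For compound 4 a step of a 7.3-fold lower number from compound 1 to compound 4 (0.87 log units; beyond the scatter) is therefore expected, in the direction of a lower number. The estimated value for compound 4 is 7000 nM, with a range from 2500 nM to 20000 nM.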

Compound 4, half-maximal inhibitory concentration: 52900 nM
Beside the measured number, compound 4's estimate is 7.6-fold (0.88 log units) below it, outside the stated range (above it).
By their numbers in this assay, from the lowest: compounds 2 and 3 (each within the scatter of the next); then compounds 1 and 4 (each within the scatter of the next).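

In this assay adding bulk at this amide-type nitrogen does not by itself lower the number: the two-ring group that takes the place of the amino group gives a 1.0-fold higher number from compound 1 to compound 4 (0.01 log units; within the scatter) and so cannot be told apart from the small hydrazide. Set against the ringless sulfur-bearing group, the same two-ring group gives an 8.5-fold higher number from compound 2 to compound 4 (0.93 log units; beyond the scatter) and thus shows that the identity of the group matters here, with compound 4 going against the lower numbers seen for compound 2 and compound 3. The data shown offer no explanation for this difference.

On these data alone, it remains open where a plain phenyl group without the two nitro groups would fall at this nitrogen. Also open, as far as these compounds go, is what an oxygen in place of the sulfur of compound 2 would do.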